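Swapping One Benzyl Group on a Stable Compound

The source may report more compounds than this note shows. Statements on the series, on what has been measured and on what is new or still open speak of the compounds shown alone.

In an ADME assay on microsomes from liver (Mus musculus) for metabolic stability, with a stated time of 10 min (on this read-out higher numbers stand for a more stable compound and lower numbers for a less stable compound), compound 3 (`O=C(O)[C@H]1CC[C@H](C(=O)N2CC[C@](c3ccc(C(OCc4ccccc4OC(F)(F)F)(C(F)(F)F)C(F)(F)F)cc3)(S(=O)(=O)c3ccc(F)cc3)C2)CC1`) gives 81% as its result. That lies within the scatter of compound 2 (`O=C(O)C1CCN(C(=O)N2CC[C@](c3ccc(C(OCc4c(F)cccc4F)(C(F)(F)F)C(F)(F)F)cc3)(S(=O)(=O)c3ccc(F)cc3)C2)CC1`), which gives 84% and cannot be told apart from it. Compound 1 (`CC(=O)N1CCN(C(=O)N2CC[C@](c3ccc(C(OCc4c(F)cccc4C#N)(C(F)(F)F)C(F)(F)F)cc3)(S(=O)(=O)c3ccc(F)cc3)C2)CC1`) gives 1% and lies far lower, well beyond the scatter.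

Compound 4 (`Cc1cccc(F)c1COC(c1ccc([C@]2(S(=O)(=O)c3ccc(F)cc3)CCN(C(=O)[C@H]3CC[C@H](C(=O)O)CC3)C2)cc1)(C(F)(F)F)C(F)(F)F`) differs from compound 3 in one place only (2-fluoro-6-methylphenyl in place of 2-(trifluoromethoxy)phenyl on a saturated chain carbon bound to an oxygen on a saturated carbon) and otherwise stays the same. Here 2-fluoro-6-methylphenyl takes the place of 2-(trifluoromethoxy)phenyl on a saturated chain carbon bound to an oxygen on a saturated carbon.

For the measured compounds named here, no measured pair isolates this swap. Compound 2 at 84% and compound 3 at 81% differ in more than one place and still agree, so only a small downward step in this assay is expected, none beyond the scatter. Compound 1 at 1% goes against that calm picture, so the range stays wide. The expected change is a number 5 percentage points lower from compound 3 to compound 4 (within the scatter) and it stays within the scatter. For compound 4 the estimate is 76% with an expected range from 55% to 90% in this read-out.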

Compound 4, percent of the compound remaining: 78%
Estimate against measurement, compound 4: 2 percentage points below; the range from low to high includes it.
By their numbers in this assay, from the lowest: compound 1; then compounds 4, 3 and 2 (each within the scatter of the next).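

In this assay, for the compounds shown here, 2-fluoro-6-methylphenyl in place of 2-(trifluoromethoxy)phenyl gives a number 3 percentage points lower from compound 3 to compound 4 (within the scatter), the first step here that isolates a single change, and the two compounds cannot be told apart. At this place, on a saturated chain carbon bound to an oxygen on a saturated carbon, the group that leaves has 11 heavy atoms and 1 hydrogen-bond acceptor, the group that enters has 8 heavy atoms and no acceptor, and the read-out stays within the scatter. Nothing shown gives a reason for this result.

Going by these compounds alone, compound 1 still stands apart at 1%, but no single-change step connects it to the other compounds, so its low number cannot be tied to any one group. As far as these compounds go, it also remains open how this read-out would respond to an amine on the benzyl group, or to a longer chain in place of the benzyl link.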